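Two-ring core with a substituted six-membered ring: aryl replacement

The source may hold more compounds than are shown below. What is called first, only, known or untested is meant among the compounds shown, and "the series" means these compounds.

Measured so far:
compound 1 `COc1ccc(NC(=O)CSc2nc3ccc(N4CCN(C)CC4)nc3[nH]2)cc1OC` gives 35% in an assay on isolated protein for inhibition of Ectonucleotide pyrophosphatase/phosphodiesterase family member 1 (Homo sapiens), tested at 10 uM; on this read-out lower numbers stand for less inhibition and higher numbers for more inhibition at the one concentration tested (going by the name of the read-out).
compound 2 `COc1ccc(NC(=O)CSc2nc3ccc(SC)nc3[nH]2)cc1OC` gives 59% in this assay.

Compound 2 holds the higher of the two numbers; compound 1 sits at the other, and the step of a number 24 percentage points higher from compound 1 to compound 2 (beyond the scatter) lies beyond the scatter. Compound 3 `COc1ccc(NC(=O)CSc2nc3ccc(N4CCCCC4)nc3[nH]2)cc1OC` is not yet measured. It differs from compound 2 as follows: piperidin-1-yl in place of methylsulfanyl on an aromatic carbon. Within the data shown here, the only measured step that bears on this place is the one from compound 1 to compound 2, where a 4-methylpiperazin-1-yl gave way to methylsulfanyl with a modest gain. Piperidin-1-yl, like 4-methylpiperazin-1-yl, is a six-membered non-aromatic ring attached through nitrogen, so compound 3 is expected to fall back toward compound 1, by an estimated a number 14 percentage points lower from compound 2 to compound 3 (beyond the scatter). Compound 3 is thus estimated at 45%, with a range from 25% to 65% in this assay.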

Compound 3, a percentage reported as inhibition, at one concentration (the size of the read-out at that concentration, not a potency): 27%
The estimate for compound 3 lay 18 percentage points above the measured number, within the range that was stated.
By their numbers in this assay, from the lowest: compounds 3 and 1 (each within the scatter of the next); then compound 2.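

In this assay, the large step of a number 32 percentage points lower from compound 2 to compound 3 (beyond the scatter) shows that a non-aromatic six-membered ring attached through nitrogen at this position, next to the ring nitrogen, gives a lower number even without the 4-methylpiperazin-1-yl group. The further step a number 8 percentage points lower from compound 1 to compound 3 (within the scatter) lies within the scatter, so this read-out does not separate piperidin-1-yl from 4-methylpiperazin-1-yl, and among these three compounds only the methylsulfanyl of compound 2 stands apart from both. Nothing available explains the difference between methylsulfanyl and the two rings.

From the compounds shown here alone, it remains open whether a methoxy group, an open-chain dimethylamino group or a longer ethylsulfanyl chain would match compound 2 or fall with the two rings. A morpholin-4-yl ring at this position is also open, and the single-concentration read-out gives no potency for any of these compounds.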